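This account rests on a few compounds, and the source may have more. Where it says the series, first, only, none or still open, it means among the compounds named here.

Measured compounds:
- compound 1 `CCCSc1nc(Nc2ccccc2)c2nc(Nc3ccccc3)sc2n1`: 35300 nM
- compound 2 `CCCSc1nc(Nc2ccc(OC)cc2)c2nc(Nc3ccccc3)sc2n1`: 30900 nM
- compound 3 `CCCSc1nc(NC2CC2)c2nc(Nc3ccccc3)sc2n1`: 32400 nM

In a functional assay on HGC-27 cells (Homo sapiens) for antiproliferative activity, read by MTT assay, with a stated time of 72 h (a lower number here means a stronger inhibitor, a higher number a weaker inhibitor), compound 2 gives the lowest of the three numbers, but its steps to the others, a 1.1-fold lower number from compound 1 to compound 2 (0.06 log units; within the scatter) and a 1.0-fold higher number from compound 2 to compound 3 (0.02 log units; within the scatter), both sit within the scatter, so the three compounds cannot be ordered on these data. Compound 4 `CCCSc1nc(Nc2ccc(Cl)cc2)c2nc(Nc3ccccc3)sc2n1` is not yet measured. Its difference from compound 2 is chloro in place of methoxy on an aromatic carbon.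

Within the data shown here, two measured steps bear on this change. The step of a 1.1-fold lower number from compound 1 to compound 2 (0.06 log units; within the scatter) shows that placing methoxy on that aromatic carbon leaves the number unchanged beyond the scatter; the step of a 1.0-fold higher number from compound 2 to compound 3 (0.02 log units; within the scatter) shows that replacing the whole 4-methoxyphenyl by cyclopropyl at that nitrogen also leaves it unchanged. Nothing measured here shows chloro at that position. Since both steps touching this part of compound 2 stay within the scatter, no step beyond the scatter is expected in this assay for chloro in place of methoxy; the expected step is a 1.0-fold higher number from compound 2 to compound 4 (0.00 log units; within the scatter). Compound 4 is therefore estimated at 31000 nM, between 15000 nM and 62000 nM.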

Compound 4, half-maximal inhibitory concentration: 20300 nM
For compound 4 the middle estimate is 1.5-fold (0.18 log units) above the measured one; the measured number falls inside the stated range.
By their numbers in this assay, from the lowest: compounds 4, 2, 3 and 1 (each within the scatter of the next).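

In this assay, among these compounds, chloro is the first group on this aromatic carbon other than hydrogen and methoxy, and chloro in place of methoxy, para to a large group, stays within the scatter (a 1.5-fold lower number from compound 2 to compound 4 (0.18 log units; within the scatter)). The same holds for chloro in place of hydrogen (a 1.7-fold lower number from compound 1 to compound 4 (0.24 log units; within the scatter)) and for 4-chlorophenyl in place of cyclopropyl on the nitrogen (a 1.6-fold lower number from compound 3 to compound 4 (0.20 log units; within the scatter)), so none of the printed steps at this position in the series goes beyond the scatter. Nothing at hand offers a reason for the size of these steps.

Still open, on these data alone, is whether any group on this aromatic carbon gives a step beyond the scatter, for example an amine, a carboxylic acid or a nitrile. Also open is a longer chain in place of the propyl chain, which all the compounds shown share.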